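The compounds below may be only part of what the source reports. "The series", "measured", "known", "first", "only" and "open" are said of these compounds alone.

Measured so far in a functional assay on A498 cells (Homo sapiens) for inhibition, read by sulforhodamine B assay, with a stated time of 48 h; a higher number here means a weaker inhibitor, a lower number a stronger inhibitor:
compound 1 `O=C(Nc1cccc(-n2cc(-c3ccncc3)c(-c3ccc(Cl)c(O)c3)n2)c1)Nc1ccc(Cl)c(Cl)c1`: 940 nM
compound 2 `O=C(Nc1cccc(-n2cc(-c3ccncc3)c(-c3ccc(Cl)c(O)c3)n2)c1)Nc1cc(C(F)(F)F)cc(C(F)(F)F)c1`: 790 nM

For the measured compounds named here, compound 1 stands at the higher of the two numbers, but its only neighbour, compound 2, lies at a gap that falls within the scatter of repeated measurements, so the two read as equivalent and neither can be called weaker or stronger. Going by the values given here, no pair of measured compounds differs in a single place, so no step size is known from the measured set itself.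

Compound 3 `O=C(Nc1cccc(-n2cc(-c3ccncc3)c(-c3ccc(Cl)c(O)c3)n2)c1)Nc1ccc(Cl)c(C(F)(F)F)c1` is the next compound to be measured. Against compound 1 the change is trifluoromethyl in place of chloro on an aromatic carbon, which, cut one bond further out, reads 3,4-dichlorophenyl to 4-chloro-3-(trifluoromethyl)phenyl. Both measured compounds carry chloro or trifluoromethyl on this ring and sit within scatter of one another, so nothing in the data points to a step beyond the scatter in either direction in this assay. The expected step is a 1.2-fold lower number from compound 1 to compound 3 (0.07 log units; within the scatter), essentially none beyond the scatter. Compound 3 is therefore estimated at 800 nM, with a range from 400 nM to 1600 nM.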

Compound 3, half-maximal inhibitory concentration: 1400 nM
Compound 3: middle estimate off by 1.8-fold (0.24 log units), on the low side; measured number inside the range.
By their numbers in this assay, from the lowest: compounds 2, 1 and 3 (each within the scatter of the next).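

Notes on the aryl urea end of the series: in this assay trifluoromethyl in place of chloro on an aromatic carbon, ortho to a chloro group and meta to a large group, gives a 1.5-fold higher number from compound 1 to compound 3 (0.17 log units; within the scatter) and so stands within the scatter. For the compounds shown here, this is the first step that reads a single place, and it shows that at this position 4 heavy atoms can stand in place of 1 with no difference that can be told from repeat measurement. No measured property of either group bears on this result, so the step carries no assigned cause.

On these data alone, both groups read here at this position are halogen-bearing, so it remains open whether the same flat reading holds for a methoxy group, an amine or a carboxylic acid at the same carbon. The chloro group in the 4-position is common to compound 1 and compound 3, so its own contribution stays unread, and a bare hydrogen or a methyl group there would be needed to separate it.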